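Swapping the aryl ether group against prostacyclin synthase

The compounds below may be only part of what the source reports. "The series", "measured", "known", "first", "only" and "open" are said of these compounds alone.

Measured compounds:
compound 1 `Cc1ccc(C#N)c(OC(C)(C)C2OCC(C/C=C\CCC(=O)O)C(c3cccnc3)O2)c1` gives > 100000 nM in an assay for inhibition of prostacyclin synthase (Homo sapiens), using microsomes (a higher number here means a weaker inhibitor, a lower number a stronger inhibitor), which is a limit of the assay and not a number.
compound 2 `Cc1ccc(OC(C)(C)C2OCC(C/C=C\CCC(=O)O)C(c3cccnc3)O2)cc1` gives 25000 nM in this assay.
compound 3 `CC(C)(Oc1ccccc1Br)C1OCC(C/C=C\CCC(=O)O)C(c2cccnc2)O1` gives 7000 nM in this assay.

Compound 1 is the weakest of the three: it sits at the limit of > 100000 nM in this assay, at which 1 of the 3 values shown sits, so only a bound is known for it, and every measured step from it is itself only a lower bound. Both the move to compound 2, an at least 4.0-fold lower number from compound 1 to compound 2 (0.60 log units; beyond the scatter), and the move to compound 3, an at least 14-fold lower number from compound 1 to compound 3 (1.15 log units; beyond the scatter), lower the number beyond the scatter, and between those two products the step of a 3.6-fold lower number from compound 2 to compound 3 (0.55 log units; beyond the scatter) favours the 2-bromophenyl ether.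

The unmeasured compound 4 `CC(C)(Oc1ccccc1[N+](=O)[O-])C1OCC(C/C=C\CCC(=O)O)C(c2cccnc2)O1` differs from compound 1 in one place: 2-nitrophenyl in place of 2-cyano-5-methylphenyl on an oxygen on a saturated carbon. Among the measured compounds shown here, of the measured steps, the one from compound 1 to compound 3 is the closest analogy, since both replace the 2-cyano-5-methylphenyl by a phenyl bearing a single substituent in the 2-position, and it was large. Compound 4 is therefore expected to give a large lowering, an at least 10-fold lower number from compound 1 to compound 4 (1.00 log units; beyond the scatter), in this assay. The estimate for compound 4 is 10000 nM, with a range of 2500 nM to 40000 nM.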

Compound 4, half-maximal inhibitory concentration: < 1000 nM
Compound 4 gave a limit, no number; the forecaster's own chance of this, stated with the estimate: 10%; middle value at least 10-fold (1.00 log units) away from the limit.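

At this position, on an oxygen on a saturated carbon, the 2-nitrophenyl group gives the lowest number of the four ethers in this assay: an at least 100-fold lower number from compound 1 to compound 4 (2.00 log units; beyond the scatter), an at least 25-fold lower number from compound 2 to compound 4 (1.39 log units; beyond the scatter) and an at least 7.0-fold lower number from compound 3 to compound 4 (0.84 log units; beyond the scatter). The last of these steps, nitro in place of bromo on an aromatic carbon, shows that two phenyl ethers differing only in that one group can lie beyond the scatter of each other, which compounds 1 to 3 could not show. Compound 4 sits at a limit of the assay and not at a number, so each of these steps is only a bound: the limit of < 1000 nM in this assay, at which 1 of the 4 values shown sits.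

From the compounds shown here alone, how much lower the true number of compound 4 lies stays open. So does whether a 2-aminophenyl or a 2-methoxyphenyl group in the same place would keep so low a number.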